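Swapping Methoxy for Methyl on Two Related Cores

The source may hold more compounds than are shown below. What is called first, only, known or untested is meant among the compounds shown, and "the series" means these compounds.

Compound 1 `COc1ccc2c(OC(C)=O)c(OC)c(OC)c(OC(C)=O)c2c1` and compound 3 `COc1c(OC)c(OC(C)=O)c2cc(C)ccc2c1OC(C)=O` share one core and differ in a single place: methyl in place of methoxy on an aromatic carbon. In a physicochemical assay for lipophilicity (on this read-out lower numbers stand for lower lipophilicity and higher numbers for higher lipophilicity), compound 1 gives 2.39, while compound 3 gives 2.86, so this exchange produced a number 0.47 log units higher from compound 1 to compound 3 (beyond the scatter). Compound 2 `CCC(=O)Oc1c(OC)c(OC)c(OC(=O)CC)c2cc(OC)ccc12` is built on a different core, which carries longer ester groups; the difference between the two cores is not broken down here. In this assay compound 2 gives 3.28, the highest of the three numbers, and its distance from compound 3 as well as from compound 1 lies beyond the usual scatter.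

Compound 4 `CCC(=O)Oc1c(OC)c(OC)c(OC(=O)CC)c2cc(C)ccc12` has not yet been measured. It differs from compound 2 by the same change that turns compound 1 into compound 3, at a place described in exactly the same words: methyl in place of methoxy on an aromatic carbon. Because that exchange once gave a number 0.47 log units higher from compound 1 to compound 3 (beyond the scatter), a step of similar size is expected in this assay, namely a number 0.47 log units higher from compound 2 to compound 4 (beyond the scatter). Compound 4 is therefore estimated at 3.75, with a likely range from 3.45 to 4.05.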

Compound 4, partition coefficient: 3.9
For compound 4 the middle estimate is 0.15 log units below the measured one; the measured number falls inside the stated range.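

In this assay, methyl in place of methoxy on an aromatic carbon went the same way on both cores, giving a number 0.47 log units higher from compound 1 to compound 3 (beyond the scatter) and a number 0.62 log units higher from compound 2 to compound 4 (beyond the scatter) for the same exchange. This shows that, across these two pairs, the direction of the step carried over from one core to the other, and each step lies beyond the usual scatter; two pairs, however, cannot establish a rule for the whole series or for cores unlike these. Nothing shown here explains the result on either core or accounts for the two steps not being identical.

The compounds shown leave open whether an ethyl group, a chlorine atom or an amine on the same aromatic carbon would follow the pattern of methyl. On these data alone, it is also open whether the exchange would give a similar step if the esters carried a longer chain or gave way to a carboxylic acid.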